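Anilinoquinazolines on PC-3 cells: a 4-bromophenyl variant

The source may hold more compounds than are shown below. What is called first, only, known or untested is meant among the compounds shown, and "the series" means these compounds.

Measured compounds:
compound 1, `COc1cc2ncnc(Nc3ccc([N+](=O)[O-])cc3)c2c(OC)c1OC`, 24.9% in a functional assay on PC-3 cells (Homo sapiens) for inhibition, read by MTT assay, with a stated time of 72 h, tested at 10 uM; a higher number here means more inhibition of growth at the concentration tested, a lower number less inhibition of growth
compound 2, `COc1cc2ncnc(Nc3cc(F)ccc3Br)c2c(OC)c1OC`, 34.7%
compound 3, `COc1cc2ncnc(Nc3cc(C(F)(F)F)ccc3Br)c2c(OC)c1OC`, 25.3%

In this assay compound 2 shows the largest of the three figures, yet neither of the other two numbers lies beyond the usual scatter of it: compound 3 sits at a number 9.4 percentage points lower from compound 2 to compound 3 (within the scatter), and compound 1 differs from compound 2 by a similar amount. The shared core carries three methoxy groups and an anilino nitrogen, and the three compounds differ only in the aryl group on that nitrogen.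

Compound 4, `COc1cc2ncnc(Nc3ccc(Br)cc3)c2c(OC)c1OC`, has not yet been measured in this assay. Compared with compound 2 the change is 4-bromophenyl in place of 2-bromo-5-fluorophenyl on a nitrogen on an aromatic ring. Among the measured compounds shown here, the one measured step on that same aryl group, a number 9.4 percentage points lower from compound 2 to compound 3 (within the scatter), stayed within the scatter, so a change of substitution there has so far moved the read-out little; compound 1, with a different substituent on the same ring, also lies within the scatter of compound 2. A step of no more than the scatter is therefore expected in this assay, with a lean toward the lower figures of compounds 1 and 3. Compound 4 is expected to give about 28%, in a range from 15% to 42%. That estimate means an expected step of a number 6.7 percentage points lower from compound 2 to compound 4 (within the scatter), within the scatter.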

Compound 4, percent growth inhibition at one concentration: 22.2%
Beside the measured number, compound 4's estimate is 5.8 percentage points above it; the range from low to high includes it.
By their numbers in this assay, from the lowest: compounds 4, 1, 3 and 2 (each within the scatter of the next, the first and the last beyond it).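

Among the steps at this place, on a nitrogen on an aromatic ring, the change to 4-bromophenyl in place of 2-bromo-5-fluorophenyl gives in this assay a number 12.5 percentage points lower from compound 2 to compound 4 (beyond the scatter), the only one to clear the scatter, and only modestly. Bromo in place of nitro on an aromatic carbon gives a number 2.7 percentage points lower from compound 1 to compound 4 (within the scatter), so this read-out does not separate those two substituents. No measurement at hand accounts for either step.

The two aryl groups differ both in the fluorine and in where the bromine sits, so the compounds shown leave open which of these differences carries the step. Going by these compounds, how an amine or a carboxylic acid on the same aryl ring would read in this assay also remains open.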